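Adding a methylthiophene to an inactive triazole amide

The source may report more compounds than this note shows. Statements on the series, on what has been measured and on what is new or still open speak of the compounds shown alone.

compound 1 `C[C@H](NC(=O)c1nnn(Cc2cccc(C(F)(F)F)c2)c1C(F)(F)F)c1ccc(C(=O)O)cc1`: > 10000 nM
compound 2 `C[C@H](NC(=O)c1cnnn1Cc1ccc(C(F)(F)F)cc1)c1ccc(C(=O)O)cc1`: > 10000 nM

Compound 1 `C[C@H](NC(=O)c1nnn(Cc2cccc(C(F)(F)F)c2)c1C(F)(F)F)c1ccc(C(=O)O)cc1` was examined in a functional assay on CHO cells for antagonist activity at prostaglandin E2 receptor EP4 subtype (Homo sapiens), read by calcium flux, with a stated time of 15 min (on this read-out lower numbers stand for stronger inhibition and higher numbers for weaker inhibition), where compound 1 gives > 10000 nM, a limit of the assay rather than a number. Compound 2 `C[C@H](NC(=O)c1cnnn1Cc1ccc(C(F)(F)F)cc1)c1ccc(C(=O)O)cc1` was examined in the same way, and in this assay compound 2 gives > 10000 nM, again a limit and not a number. Compound 2 thus stands at the limit of > 10000 nM in this assay, at which 2 of the 2 values shown sit, and nothing separates it from compound 1 on the numbers shown.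

Compound 3 `Cc1ccc(-c2nnn(Cc3ccc(C(F)(F)F)cc3)c2C(=O)N[C@@H](C)c2ccc(C(=O)O)cc2)s1` differs from compound 2 by 5-methylthiophen-2-yl in place of hydrogen on an aromatic carbon. Among the measured compounds shown here, no step between two measured compounds exists here, so the size of this change has no precedent in the data. The step of an at least 5.0-fold lower number from compound 2 to compound 3 (0.69 log units; beyond the scatter) is expected to go toward stronger inhibition, though with wide uncertainty. Compound 3 is estimated at 2000 nM in this assay, within a range of 150 nM to 10000 nM.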

Compound 3, half-maximal inhibitory concentration: 4.6 nM
Compound 3: the middle estimate sits 430-fold (2.64 log units) above what was measured; measured number below the stated range.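

In this assay, putting 5-methylthiophen-2-yl in place of hydrogen gives an at least 2100-fold lower number from compound 2 to compound 3 (3.33 log units; beyond the scatter), so a single substituent on this aromatic carbon of the five-membered ring with 3 nitrogen is enough to carry the series from no measurable inhibition to a low number. This is the first change shown that moves a compound off the limit of the assay, and it shows that this position tolerates an added aromatic ring and can decide the outcome. The full size of the step stays unknown, because compound 2 gives only a limit and not a number: the limit of > 10000 nM in this assay, at which 2 of the 3 values shown sit.

On these data alone, whether the gain needs the whole 5-methylthiophen-2-yl group remains open, since a plain thiophene, a phenyl, a pyridine or a single methyl at this carbon could do as much or far less. Also open, as far as these compounds go, is whether the carboxylic acid and the 4-(trifluoromethyl)benzyl group are needed once this group is in place.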